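The source may hold more compounds than are shown below. What is called first, only, known or untested is meant among the compounds shown, and "the series" means these compounds.

Compound 3, with the structure `Cc1c(C#N)c(-c2ccccc2)nn1CCCN1CCN(c2cccc(Cl)c2)CC1`, is one of three compounds tested in a functional assay on the whole organism (Abdomen, strain Swiss) for inhibition, with Mus musculus as the target, with stated times of 30 min, 10 min and 5 min, at a dose of 40 mg/kg by the oral route; on this read-out higher numbers stand for a stronger effect at the one dose given and lower numbers for a weaker effect. In this assay compound 3 gives 23%, the lowest of the three numbers. Compound 1, with the structure `CCc1nn(CCCN2CCN(c3ccc(C)cc3)CC2)c(=O)c(N)c1C(C)=O`, gives 41%, and compound 2, with the structure `Cc1c(C#N)c(-c2ccccc2)nn1CCCN1CCN(c2ccc(F)cc2)CC1`, gives 51%; the gap from compound 3 to each of these lies beyond the usual scatter. Going by the values given here, the single step between two compounds that differ in one place is a number 28 percentage points lower from compound 2 to compound 3 (beyond the scatter), which came from exchanging the substituted phenyl ring on the amine nitrogen in a ring.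

Compound 4, with the structure `COc1cccc(N2CCN(CCCn3nc(-c4ccccc4)c(C#N)c3C)CC2)c1`, differs from compound 3 in one place: methoxy in place of chloro on an aromatic carbon. Among the compounds with values here, no measured pair compares methoxy with chloro, so the only step that bears on this change is the modest one from compound 2 to compound 3, which shows that the read-out answers to alterations on this same ring but gives no direction for the present exchange. The expectation is therefore a small step, a number 7 percentage points higher from compound 3 to compound 4 (within the scatter), that may well fall within the scatter. Compound 4 is estimated to give 30%, with a range from 10% to 55%.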

Compound 4, a percentage reported as inhibition, in the whole organism at one dose (the size of the read-out at that dose, not a potency): 34%
For compound 4 the middle estimate is 4 percentage points below the measured one, within the range that was stated.
By their numbers in this assay, from the lowest: compound 3; then compounds 4, 1 and 2 (each within the scatter of the next, the first and the last beyond it).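

With the group held in the same place on the ring, meta to a large group, the change from chloro to methoxy alone gives a number 11 percentage points higher from compound 3 to compound 4 (beyond the scatter) in this assay, so the read-out at this position responds to the group itself. The earlier step from 4-fluorophenyl to 3-chlorophenyl changed both the group and its place on the ring, so it could not show this. The second new step, a number 17 percentage points lower from compound 2 to compound 4 (beyond the scatter), shows that the 3-methoxyphenyl compound also stays under the 4-fluorophenyl compound, so both compounds with a group at this place give lower numbers than compound 2, though there is no measurement that explains either step.

The compounds shown do not separate the effect of the group from the effect of its place, since fluoro is seen only on the 4-fluorophenyl ring, and chloro and methoxy only at the other place. On these data alone, it also remains open how the read-out would respond to a hydroxyl group or an amine at this same place, or to a phenyl ring with no group on it at all.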